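The source may hold more compounds than are shown below. What is called first, only, known or untested is meant among the compounds shown, and "the series" means these compounds.

Compound 2 `Cc1ccc(-n2cc(NC(=O)c3ccc(NS(=O)(=O)c4ccccc4)cc3)cn2)cc1` gives 27900 nM in a functional assay on HeLa cells (Homo sapiens) for inhibition, read by MTT assay, with a stated time of 48 h (a lower number here means a stronger inhibitor, a higher number a weaker inhibitor), and compound 1 `O=C(Nc1cnn(-c2ccccc2)c1)c1ccc(NS(=O)(=O)c2ccccc2)cc1` gives 37100 nM in this assay; the two numbers lie within the scatter of each other, so neither compound can be ranked ahead of the other. Among the measured compounds shown here, the only measured step of a 1.3-fold lower number from compound 1 to compound 2 (0.12 log units; within the scatter) is methyl in place of hydrogen on an aromatic carbon of the group on the aromatic nitrogen. Compound 3 `COc1cccc(-n2cc(NC(=O)c3ccc(NS(=O)(=O)c4ccccc4)cc3)cn2)c1` carries 3-methoxyphenyl in place of 4-methylphenyl on an aromatic nitrogen. That change touches the same group on the aromatic nitrogen as the measured step, which did not move this assay beyond the scatter; nothing measured here separates methoxyphenyl from methylphenyl, so no step beyond the scatter is expected in this assay in either direction. The expected step is a 1.0-fold higher number from compound 2 to compound 3 (0.00 log units; within the scatter). Compound 3 is therefore estimated at 28000 nM with a range from 10000 nM to 75000 nM.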

Compound 3, half-maximal inhibitory concentration: 66200 nM
Estimate against measurement, compound 3: 2.4-fold (0.37 log units) below, and the stated range covers the measured number.
By their numbers in this assay, from the lowest: compounds 2, 1 and 3 (each within the scatter of the next, the first and the last beyond it).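

Among the compounds shown here, on the group on the aromatic nitrogen, 3-methoxyphenyl in place of 4-methylphenyl gives the first step beyond the scatter in this assay: a 2.4-fold higher number from compound 2 to compound 3 (0.38 log units; beyond the scatter), which is modest. The other new step does not separate its pair, as a 1.8-fold higher number from compound 1 to compound 3 (0.25 log units; within the scatter) stays within the scatter, so this position has so far responded only where 3-methoxyphenyl is set against 4-methylphenyl. No evidence bearing on the origin of this step is at hand.

The compounds shown leave open whether the step follows the methoxy group or its place on the phenyl ring, a question that 4-methoxyphenyl or 3-methylphenyl on the same nitrogen would separate. Also open, on these data alone, is whether an amine or a carboxylic acid on that phenyl ring would give a larger step in either direction.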